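Aryl exchange from compound 3 to compound 4

The source may hold more compounds than are shown below. What is called first, only, known or untested is meant among the compounds shown, and "the series" means these compounds.

compound 1 `CC1(COc2ncc(-c3ccc(F)nc3)cn2)CCn2cc([N+](=O)[O-])nc2O1`: > 64000 nM, a limit
compound 2 `CC1(COc2ncc(-c3ccc(F)cc3)cn2)CCn2cc([N+](=O)[O-])nc2O1`: 57000 nM
compound 3 `O=[N+]([O-])c1cn2c(n1)OC(COc1ncc(-c3ccc(F)cc3)cn1)CC2`: > 64000 nM, a limit

In an ADME assay on MRC5 cells (Homo sapiens) for cytotoxicity, read by resazurin assay, with a stated time of 72 h (a higher number here means a weaker inhibitor, a lower number a stronger inhibitor), compound 3 gives > 64000 nM. From the compounds shown here alone, that value is a limit and not a number, so the exact place of compound 3 in the series is unknown. The series as a whole shows (the limit of > 64000 nM in this assay, at which 2 of the 3 values shown sit).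

Compound 4 `O=[N+]([O-])c1cn2c(n1)OC(COc1ncc(-c3ccc(F)nc3)cn1)CC2` carries 6-fluoropyridin-3-yl in place of 4-fluorophenyl on an aromatic carbon. The closest measured step is the same exchange run the other way, in the methyl-bearing pair: an at least 1.1-fold lower number from compound 1 to compound 2 (0.05 log units; that floor lies within the scatter). The second measured step, hydrogen in place of methyl on a saturated ring carbon, bears on the transfer to the compounds without that methyl: an at least 1.1-fold higher number from compound 2 to compound 3 (0.05 log units; that floor lies within the scatter). Both steps are known only as floors.

On this evidence no step beyond the scatter is expected in this assay, in either direction. The estimated step is a number no higher from compound 3 to compound 4 (the limit leaves the size open). For compound 4 the expected value is 64000 nM, with an estimated range of 40000 nM to 100000 nM, and a report as a limit is the likely outcome.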

Compound 4, half-maximal inhibitory concentration: > 64000 nM
Compound 4: no number, only a limit; the forecaster's own chance of this, stated with the estimate: 85%; the middle value lies on the limit itself.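

No new step can be read from compound 3 to compound 4 or from compound 1 to compound 4, because each pair joins two limits in this assay: the limit of > 64000 nM in this assay, at which 3 of the 4 values shown sit.

Still open, from the compounds shown here alone, is where compound 1, compound 3 and compound 4 actually lie, and so whether either exchange shifts the read-out.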